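The source may hold more compounds than are shown below. What is called first, only, known or untested is meant among the compounds shown, and "the series" means these compounds.

Measured so far in a functional assay on S1 cells (Homo sapiens) for cytotoxicity, read by MTT assay, with a stated time of 72 h (a lower number here means a stronger inhibitor, a higher number a weaker inhibitor), are three compounds:

Compound 1 `COc1cc(/C=C/c2cc(C)[nH]n2)ccc1O` gives 29400 nM
Compound 2 `Cc1cc(/C=C/c2ccc(O)c(O)c2)on1` gives 7900 nM
Compound 3 `Cc1cc(/C=C/c2ccc(O)c(O)c2)[nH]n1` gives 55300 nM

Compound 2 stands lowest of the three, at 7900 nM on this scale, and both other compounds lie beyond the scatter from it. That makes compound 2 the strongest inhibitor of the set. Compound 1 at 29400 nM and compound 3 at 55300 nM lie within the scatter of each other.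

Compound 4 `Cc1cc(/C=C/c2ccc(O)cc2)on1` has not yet been measured. It departs from compound 2 by a single change, hydrogen in place of hydroxy on an aromatic carbon, ortho to a hydroxy group and meta to a group of 8 heavy atoms, counted in full as hydrogen in place of hydroxy on an aromatic carbon for this swap. Among the measured compounds shown here, no measured pair in the set isolates that change, so any forecast rests on little. Compound 2 at 7900 nM already holds the lowest number, which makes a move toward a higher number, and so a weaker inhibitor, the likelier direction. A change beyond the scatter is expected, estimated as a 3.5-fold higher number from compound 2 to compound 4 (0.55 log units; beyond the scatter) in this assay for this pair. The expected value for compound 4 is 28000 nM with an estimated range from 10000 nM to 80000 nM as the measurement awaits.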

Compound 4, half-maximal inhibitory concentration: 44200 nM
The estimate for compound 4 lay 1.6-fold (0.20 log units) below the measured number, and the stated range covers the measured number.
By their numbers in this assay, from the lowest: compound 2; then compounds 1, 4 and 3 (each within the scatter of the next).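

Hydrogen in place of hydroxy on an aromatic carbon, ortho to a hydroxy group and meta to a group of 8 heavy atoms, gives a 5.6-fold higher number from compound 2 to compound 4 (0.75 log units; beyond the scatter) in this assay and is the first change in this set that can be read in isolation. It shows that this position is not indifferent on this core, as the loss of a single hydroxy, with its one oxygen atom, is enough to move the number beyond the scatter. The compound that keeps the hydroxy is the stronger inhibitor of this pair, and nothing at hand explains the step.

The compounds shown leave open whether a hydroxy as such is needed at this place, or whether an amine or a fluorine atom there would keep the stronger inhibition of compound 2. They also leave open whether the same swap would give a step of similar size on the core of compound 3, so the finding holds for this one pair only.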